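The source may hold more compounds than are shown below. What is called first, only, known or untested is meant among the compounds shown, and "the series" means these compounds.

Measured compounds:
compound 1, `COC(=O)[C@H](C)[C@H]1CC[C@@](C)(CCC2=C(C)CCCC2(C)C)OO1`, > 25000 nM
compound 2, `C=C1CCC[C@H]2[C@](C)(CC[C@]3(C)CC[C@H]([C@@H](C)C(=O)O)OO3)[C@@H](C)CC[C@]12C`, 1570 nM
compound 3, `C=C1CCCC(C)(C)C1CC[C@@]1(C)CC[C@H]([C@@H](C)C(=O)O)OO1`, 9240 nM

All three were tested in a functional assay on SK-OV-3 cells (Homo sapiens) for inhibition; on this read-out higher numbers stand for weaker inhibition of growth and lower numbers for stronger inhibition of growth. For compound 1 the value > 25000 nM is a limit of the assay and not a number, as recorded in the limit of > 25000 nM in this assay, at which 1 of the 3 values shown sits. Compound 2 gives 1570 nM. Compound 3 gives 9240 nM, the higher of the two numbers obtained; its nearest neighbour is compound 2, whose number is lower by a margin that lies beyond the usual scatter of this assay.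

The step now followed leads from compound 3 to compound 4, `C=C1CCCC(C)(C)C1CC[C@]1(C)CC[C@@H]([C@@H](C)C(=O)O)OO1`, which has not yet been tested in this assay. The difference between them is the two compounds have the same atoms and bonds; at least one stereo element is drawn with a configuration in one of them and without one in the other: 2 of 4 stereo elements differ; a stereocentre at a saturated ring carbon is drawn S in compound 3 and R in compound 4; a stereocentre at a saturated ring carbon is drawn R in compound 3 and S in compound 4. For the measured compounds named here, no pair of measured compounds differs in this way, so there is no measured step to lean on. Inverting two stereocentres in a ring can shift a growth-inhibition value in either direction; the expectation here is a step of moderate size, with the direction left open. Compound 4 is therefore estimated at 9000 nM, within a range from 2500 nM to 30000 nM, which corresponds to an expected step of a 1.0-fold lower number from compound 3 to compound 4 (0.01 log units; within the scatter).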

Compound 4, concentration for 50% growth inhibition: > 10000 nM
Compound 4: only a limit was reported (the forecaster's own chance of this, stated with the estimate: 15%); middle value at least 1.1-fold (0.04 log units) away from the limit.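

In this assay compound 4 gives > 10000 nM, which is a limit of the assay and not a number. Read as a change, this is an at least 1.0-fold higher number from compound 3 to compound 4 (0.03 log units; that floor lies within the scatter), so the data establish no loss of growth inhibition beyond the scatter, though they do not exclude a large one. What this pair adds is the only stereochemical comparison among the compounds shown: with atoms and bonds unchanged, inverting two stereocentres at saturated ring carbons brought no stronger inhibition of growth.

The limit leaves open how far the true value of compound 4 lies from that of compound 3, and the pair cannot say whether either stereocentre alone would matter, since both are inverted together. Going by these compounds, it is also open whether the same inversion would behave alike on the larger core of compound 2, or in a compound carrying an amide in place of the carboxylic acid.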